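Sulfur in Place of Oxygen on the Side Chain

A few compounds are considered here, and "the series" means these few. Any claim that something is new, unique, unknown or untested is made for them only; others in the source may bear on it.

Within the data shown here, compound 2 `CCNC(=O)NCC1CCc2ccccc2N1` is the stronger of the two compounds measured so far. In an assay on CHO cells for displacement of a labelled ligand from melatonin receptor type 1A (Homo sapiens), with a stated time of 120 min (a higher number here means a weaker inhibitor, a lower number a stronger inhibitor), compound 2 gives 115 nM, the lowest of the two numbers. Among the measured compounds shown here, its only measured neighbour, compound 1 `CCNC(=O)NCC1CCc2c(cccc2OC)N1`, gives 480 nM in this assay; the step of a 4.2-fold lower number from compound 1 to compound 2 (0.62 log units; beyond the scatter) came with hydrogen in place of methoxy on an aromatic carbon. Compound 3 `CCNC(=S)NCC1CCc2ccccc2N1` differs from compound 2 at another place: a group of 5 heavy atoms (3 carbon, 1 nitrogen, 1 sulfur; no ring) in place of a group of 5 heavy atoms (3 carbon, 1 nitrogen, 1 oxygen; no ring), on an amine nitrogen. For the measured compounds named here, no measured step touches this part of the molecule; the one step available, a 4.2-fold lower number from compound 1 to compound 2 (0.62 log units; beyond the scatter), concerns a different position and so gives no direct guide. With the shared core and the remainder of the chain unchanged, compound 3 is expected to stay near compound 2, the estimated step of a 1.3-fold higher number from compound 2 to compound 3 (0.12 log units; within the scatter) lying within the scatter. Compound 3 is estimated at 150 nM, with a range from 40 nM to 600 nM.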

Compound 3, inhibition constant: 305 nM
Compound 3: middle estimate off by 2.0-fold (0.31 log units), on the low side, within the range that was stated.
By their numbers in this assay, from the lowest: compound 2; then compounds 3 and 1 (each within the scatter of the next).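

Among these compounds, until this result, the only measured change lay on an aromatic carbon, so nothing showed whether the side chain mattered. It does matter in this assay: putting sulfur in place of oxygen in the ethylcarbamoyl group, on the amine nitrogen, gave a 2.7-fold higher number from compound 2 to compound 3 (0.42 log units; beyond the scatter), even though the counts of hydrogen-bond donors and acceptors are the same on both sides of the change, so those counts alone do not settle the number. No measurement at hand says why the number moved.

The compounds shown leave open how a different group on this amine nitrogen would fare, such as propylcarbamoyl with its longer chain, or acetyl. They also leave open whether methoxy on the aromatic carbon would bring the same kind of step when the side chain carries sulfur.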